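Cytotoxicity limits and the dipropylamino step

The compounds below may be only part of what the source reports. "The series", "measured", "known", "first", "only" and "open" are said of these compounds alone.

Of the compounds shown here, two have been read in an ADME assay on MT4 cells (Homo sapiens) for cytotoxicity, read by MTT assay, with a stated time of 4 days (a higher number here means that more compound is tolerated, a lower number that less compound is tolerated), so far. Compound 1 (`CCCN(CCC)c1nc(Cc2c(F)cccc2F)cc(=O)[nH]1`) gives > 78000 nM as a limit of the assay and not a number. Compound 2 (`Cc1c(Cc2c(F)cccc2F)nc(N(C)C2CCCCC2)[nH]c1=O`) gives > 72000 nM and this too is a limit. Compound 2 therefore has no exact value, and the only other result is also a limit, so no order can be stated between the two.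

Compound 3 (`CCCN(CCC)c1nc(Cc2c(F)cccc2F)c(C)c(=O)[nH]1`) has dipropylamino in place of cyclohexyl(methyl)amino on an aromatic carbon between two ring nitrogen atoms (dipropylamino in place of cyclohexyl(methyl)amino on an aromatic carbon). With no exact value to work from, the expectation rests on the limit of compound 2 at > 72000 nM in this series. The expected change a number no higher from compound 2 to compound 3 (the limit leaves the size open) is none beyond the scatter. Compound 3 is estimated at 72000 nM with an expected range of 30000 nM to 110000 nM and will probably be reported only as a limit.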

Compound 3, half-maximal cytotoxic concentration: > 74000 nM
Compound 3 ended at the assay's limit; the forecaster's own chance of this, stated with the estimate: 80%; middle value at least 1.0-fold (0.01 log units) from the limit.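

In this assay compound 3 gives > 74000 nM, a limit of the assay and not a number. Compound 1 and compound 2 also stand at limits, so neither step to compound 3 can be read. Going by these compounds, the half-maximal cytotoxic concentration of all three compounds stays open.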